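Compound 2 at the assay limit, and one chloro step

The compounds below may be only part of what the source reports. "The series", "measured", "known", "first", "only" and "open" are said of these compounds alone.

Of the compounds shown here, two sharing one core have been tested in a functional assay on MDA-MB-468 cells (Homo sapiens) for antiproliferative activity, read by MTT assay, with a stated time of 24 h; a lower number here means a stronger inhibitor, a higher number a weaker inhibitor. Compound 1 `CNC(=O)c1ccccc1Oc1nc(Nc2ccc(C(F)(F)F)cc2)ncc1Br` returns only a limit, > 50000 nM. Compound 2 `CNC(=O)c1ccccc1Oc1nc(Nc2ccccc2F)ncc1Br` likewise returns only a limit, > 50000 nM. The data therefore show (the limit of > 50000 nM in this assay, at which 2 of the 2 values shown sit), and neither compound has a true number to rank it by.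

Compound 3 `CNC(=O)c1ccccc1Oc1nc(Nc2ccc(Cl)cc2F)ncc1Br` differs from compound 2 by a single change: chloro in place of hydrogen on an aromatic carbon. For the measured compounds named here, no measured step shows what such a change does, so the expectation rests on the limit of compound 2, > 50000 nM. No shift beyond the scatter is expected in this assay, in either direction. The estimated step is a number no higher from compound 2 to compound 3 (the limit leaves the size open). Compound 3 is expected at about 50000 nM, with an estimated range from 20000 nM to 100000 nM.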

Compound 3, half-maximal inhibitory concentration: > 50000 nM
Compound 3: a limit, no number (the forecaster's own chance of this, stated with the estimate: 65%); the middle value lies on the limit itself.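

Compound 3, like compound 2, returns only a limit in this assay, so no step can be read between compound 2 and compound 3: the limit of > 50000 nM in this assay, at which 3 of the 3 values shown sit. The compounds shown leave open whether chloro in place of hydrogen changes anything in this assay, since none of them has a true number.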